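A few compounds are considered here, and "the series" means these few. Any claim that something is new, unique, unknown or untested is made for them only; others in the source may bear on it.

Compound 1 `COc1cc(-c2cccc3nc(-c4ccccc4)oc23)cc(OC)c1OC`: in a functional assay on U-251 cells (Homo sapiens) for antiproliferative activity, read by MTT assay, with a stated time of 48 h (on this read-out higher numbers stand for weaker inhibition and lower numbers for stronger inhibition), compound 1 gives 3500 nM.
Compound 2 `COc1cccc(-c2nc3cccc(-c4cc(OC)c(OC)c(OC)c4)c3o2)c1`: in this assay compound 2 gives > 25000 nM, which is a limit of the assay rather than a number.
Compound 3 `COc1cc(-c2cccc3nc(-c4ccc(F)cc4)oc23)cc(OC)c1OC`: in this assay compound 3 gives > 25000 nM, again a limit and not a number.

On these data alone, compound 3 therefore stands at the weak end of the series, at the limit of > 25000 nM in this assay, at which 2 of the 3 values shown sit, so its exact position is unknown.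

Compound 4 `COc1cc(-c2cccc3nc(-c4ccc(Cl)cc4)oc23)cc(OC)c1OC` differs from compound 3 by chloro in place of fluoro on an aromatic carbon.

Going by the values given here, two measured steps touch this region. Adding fluoro produced an at least 7.1-fold higher number from compound 1 to compound 3 (0.85 log units; beyond the scatter). The comparison between the two limits, a step that the two limits leave unreadable from compound 2 to compound 3, gives no readable size. Among the compounds with values here, no measured step exchanges one halogen for another, so the change from compound 3 to compound 4 has no direct precedent here.

With compound 3 already at a limit, compound 4 is expected to remain near it, and the step that the limit leaves unreadable from compound 3 to compound 4 is expected to be none beyond the scatter. Compound 4 is thus estimated at 30000 nM, with a range from 8000 nM to 100000 nM.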

Compound 4, half-maximal inhibitory concentration: 1600 nM
For compound 4 the middle estimate is 19-fold (1.27 log units) above the measured one; measured number below the stated range.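

In this assay, the choice of halogen on this six-membered aromatic ring matters greatly: chloro in place of fluoro gives an at least 15-fold lower number from compound 3 to compound 4 (1.19 log units; beyond the scatter), so the two halogens are not interchangeable here. Chloro in place of hydrogen gives a 2.2-fold lower number from compound 1 to compound 4 (0.34 log units; beyond the scatter), and 4-chlorophenyl in place of 3-methoxyphenyl gives an at least 15-fold lower number from compound 2 to compound 4 (1.19 log units; beyond the scatter), which makes compound 4 the first compound shown in which a group added to this phenyl ring lowers the number, unlike compound 2 and compound 3. The values of compound 2 and compound 3 are limits and not numbers, so the steps from them have only one readable end: the limit of > 25000 nM in this assay, at which 2 of the 4 values shown sit.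

On these data alone, it remains open whether this gain is special to chloro or extends to other groups at this position, such as bromo, methyl or an amine. As far as these compounds go, it is also open whether chloro would have the same effect elsewhere on this ring.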